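A methyl on the pendant ring of compound 3

The source may report more compounds than this note shows. Statements on the series, on what has been measured and on what is new or still open speak of the compounds shown alone.

The compound set holds three measured sulfones built on a shared core. Compound 1 `O=S(=O)(c1ccccc1)c1cnc2cc(-c3ccc(Cl)cc3)nn2c1-c1ccc(Br)cc1` gives 24.7% in a functional assay on the whole organism for inhibition, with Mus musculus as the target, with a stated time of 2 h, at a dose of 50 mg/kg by the oral route; a higher number here means more inhibition at the dose given (going by the name of the read-out), a lower number less inhibition. Compound 2 `Cc1ccc(-c2c(S(=O)(=O)c3ccccc3)cnc3c(Br)c(-c4ccccc4)nn23)cc1` gives 61% in this assay, and compound 3 `Cc1ccc(-c2c(S(=O)(=O)c3ccccc3)cnc3cc(-c4ccccc4)nn23)cc1` gives 41%. Compound 3 stands second of the three numbers: compound 1 is lower beyond the scatter, and compound 2 is higher beyond the scatter. Among the compounds with values here, the one step between neighbours that differ in one place, a number 20 percentage points lower from compound 2 to compound 3 (beyond the scatter), concerns hydrogen in place of bromo on an aromatic carbon of the core and does not touch the ring altered here.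

Compound 4 `Cc1ccc(-c2cc3ncc(S(=O)(=O)c4ccccc4)c(-c4ccc(C)cc4)n3n2)cc1` differs from compound 3 by methyl in place of hydrogen on an aromatic carbon, which read one bond further out is phenyl to 4-methylphenyl. Within the data shown here, no measured step covers a methyl on this ring, so the data offer no direction for it. Compound 4 is therefore expected to stay close to compound 3, with an estimated step of a number 3 percentage points higher from compound 3 to compound 4 (within the scatter), within the scatter. Compound 4 is estimated at 44% in this assay, between 24% and 64%.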

Compound 4, a percentage reported as inhibition, in the whole organism at one dose (the size of the read-out at that dose, not a potency): 42.6%
The estimate for compound 4 lay 1.4 percentage points above the measured number; measured number inside the range.
By their numbers in this assay, from the lowest: compound 1; then compounds 3 and 4 (each within the scatter of the next); then compound 2.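

In this assay, within the data shown here, the step of a number 1.6 percentage points higher from compound 3 to compound 4 (within the scatter) is the first reading on the pendant ring, and it places methyl in place of hydrogen, para to a large group, within the usual scatter. This sets the ring apart from the core, where the earlier step of a number 20 percentage points lower from compound 2 to compound 3 (beyond the scatter) lay beyond the scatter, although that step involved bromo rather than methyl. Nothing measured on these compounds bears on the reason for this result.

Methyl is the only group shown on this ring, so it remains open whether a methoxy, an amine or a carboxylic acid in the same place would move the number beyond the scatter. Also open, from the compounds shown here alone, is whether the methyl would give a similar reading with bromo on the core, as in compound 2.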